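A few compounds are considered here, and "the series" means these few. Any claim that something is new, unique, unknown or untested is made for them only; others in the source may bear on it.

Working notes on the series. In a functional assay on Hs-578T cells (Homo sapiens) for cytotoxicity, read by sulforhodamine B assay, with a stated time of 48 h, tested at 0.1 uM (on this read-out lower numbers stand for a stronger effect and higher numbers for a weaker effect at the one concentration tested), compound 1 `COc1cc(-c2cc(/C=C/C(=O)c3ccc(N)cc3)[nH]n2)cc(OC)c1OC` gives 88%. Compound 2 `COc1ccc(-c2cc(/C=C/C(=O)c3ccc(N)cc3)[nH]n2)cc1OC` gives 93% in this assay, and compound 3 `COc1ccc(-c2cc(/C=C/C(=O)c3cc(OC)c(OC)c(OC)c3)[nH]n2)cc1OC` gives 97%. On these three numbers compound 1 stands at the low end, with compound 2 nearest and compound 3 furthest, but both gaps lie within the scatter, so none of the three can be called stronger or weaker than another. For the measured compounds named here, the only step between measured compounds that differ in one place is a number 5 percentage points higher from compound 1 to compound 2 (within the scatter), a hydrogen in place of a methoxy on an aromatic carbon, and it stays within the scatter.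

Compound 4 `COc1ccc(C(=O)/C=C/c2cc(-c3cc(OC)c(OC)c(OC)c3)n[nH]2)cc1OC` is not yet measured. Against compound 1 the change is 3,4-dimethoxyphenyl in place of 4-aminophenyl on a carbonyl carbon. Going by the values given here, no measured step touches this place on the carbonyl carbon; the step from compound 1 to compound 2 concerns another part of the molecule. Compound 3, which carries a trimethoxyphenyl on the carbonyl carbon, shows a number in the same region as compound 1 and compound 2. All three measured numbers sit close together, so the step of a number 4 percentage points higher from compound 1 to compound 4 (within the scatter) is expected to stay within the scatter, with no direction favoured. Compound 4 is estimated at 92%, within a range from 80% to 102%.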

Compound 4, a percentage reported as activity, at one concentration (the size of the read-out at that concentration, not a potency): 99%
Estimate against measurement, compound 4: 7 percentage points below; measured number inside the range.
By their numbers in this assay, from the lowest: compounds 1, 2, 3 and 4 (each within the scatter of the next, the first and the last beyond it).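

In this assay, for the compounds shown here, the change on the carbonyl carbon gives a number 11 percentage points higher from compound 1 to compound 4 (beyond the scatter), and this is the first step to lie beyond the scatter; the one earlier step concerned another part of the molecule and stayed within it. This place therefore responds to a change of group, and 3,4-dimethoxyphenyl in place of 4-aminophenyl goes with a weaker effect at the one concentration tested, although the step is modest and rests on a single pair. Nothing on hand accounts for the size or direction of this step.

The change removes the amine and adds two methoxy groups in one move, so the compounds shown do not tell which part of it carries the step; an unsubstituted phenyl, a 4-hydroxyphenyl or a 4-methoxyphenyl on the carbonyl carbon of the core of compound 1 would separate the two. Also open, on these data alone, is whether the step holds at other concentrations, since a reading at one concentration is not a potency.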